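The source may hold more compounds than are shown below. What is called first, only, known or untested is meant among the compounds shown, and "the series" means these compounds.

Measured compounds:
Compound 1, `CCc1ccccc1C(=O)Nc1ccc2nc(N3CCN(CC)CC3)cc(C)c2c1`: 15800 nM
Compound 2, `CCN1CCN(c2cc(C)c3cc(NC(=O)c4ccc(F)c(F)c4)ccc3n2)CC1`: 5230 nM

Going by the values given here, in a functional assay on MCF7 cells (Homo sapiens) for antiproliferative activity, read by MTT assay, with a stated time of 72 h (on this read-out lower numbers stand for stronger inhibition and higher numbers for weaker inhibition), compound 2 holds the lowest of the two numbers, and the one step measured so far is a 3.0-fold lower number from compound 1 to compound 2 (0.48 log units; beyond the scatter), a change of the group on the carbonyl carbon. Compound 3, `CCN1CCN(c2cc(C)c3cc(NC(=O)c4ccco4)ccc3n2)CC1`, differs from compound 2 in the same place: furan-2-yl in place of 3,4-difluorophenyl on a carbonyl carbon. The measured step bears on it only loosely, since neither group of that step is furan-2-yl; it shows that exchanging the group on the carbonyl carbon can move the number by a modest amount in either direction. Among the compounds with values here, with no closer precedent, the expectation for compound 3 is a small step, more likely toward a higher number than a lower one, as a 1.7-fold higher number from compound 2 to compound 3 (0.24 log units; within the scatter). Compound 3 is therefore estimated at 9000 nM, within a range from 3000 nM to 27000 nM.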

Compound 3, half-maximal inhibitory concentration: 41200 nM
For compound 3 the middle estimate is 4.6-fold (0.66 log units) below the measured one; measured number outside the range, above it.
By their numbers in this assay, from the lowest: compound 2; then compound 1; then compound 3.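

In this assay, the group on the carbonyl carbon proves to matter more than the first pair suggested: replacing 3,4-difluorophenyl with furan-2-yl gives a 7.9-fold higher number from compound 2 to compound 3 (0.90 log units; beyond the scatter), a larger step than any seen before. Replacing 2-ethylphenyl with furan-2-yl also gives a 2.6-fold higher number from compound 1 to compound 3 (0.42 log units; beyond the scatter), so among these three compounds, both groups built on a six-membered carbon ring give lower numbers than the five-membered ring with its oxygen. Nothing available here explains this difference.

On these data alone, it remains open whether the higher number belongs to furan-2-yl in particular or would appear with other small rings, such as thiophen-2-yl or an unsubstituted pyridine ring, on the same carbonyl carbon. A plain phenyl group would also show how much the fluorine atoms and the ethyl chain each contribute.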